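A Cyclohexyl Group on the Thiosemicarbazone Compound

The source may hold more compounds than are shown below. What is called first, only, known or untested is meant among the compounds shown, and "the series" means these compounds.

In an ADME assay on BHK-21 cells (Mesocricetus auratus) for cytotoxicity, read by MTT assay (a lower number here means that less compound is tolerated, a higher number that more compound is tolerated), the measured values are these.
Compound 1 `COc1ccc(-c2nc3cc(/C(C)=N/NC(N)=O)ccc3[nH]2)c(OC)c1` gives >= 100000 nM (a limit of the assay)
Compound 2 `COc1ccc(-c2nc3cc(/C(C)=N/NC(N)=S)ccc3[nH]2)c(OC)c1` gives 28000 nM

For the measured compounds named here, compound 2 holds the only actual number in this small set. Compound 1 stands at the limit of >= 100000 nM in this assay, at which 1 of the 2 values shown sits, and so offers a limit rather than a number.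

Compound 3 `COc1ccc(-c2nc3cc(/C(C)=N/NC(N)=S)ccc3n2C2CCCCC2)c(OC)c1` differs from compound 2 as follows: cyclohexyl in place of hydrogen on an aromatic nitrogen. In short, cyclohexyl replaces hydrogen on an aromatic nitrogen. Going by the values given here, no measured step covers a change at that nitrogen. Among the compounds with values here, the nearest evidence is an at least 3.5-fold lower number from compound 1 to compound 2 (0.55 log units; beyond the scatter), a change on an amine nitrogen that shows only that compound 2 is already sensitive to a change elsewhere in the molecule. That step gives a weak guide to size and none to direction at the new place. A modest move towards a lower number in this assay is therefore expected, though a result within the scatter would be no surprise. The expected change is a 1.6-fold lower number from compound 2 to compound 3 (0.19 log units; within the scatter). For compound 3 the estimate is 18000 nM, with an expected range from 5000 nM to 60000 nM.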

Compound 3, half-maximal cytotoxic concentration: 17000 nM
Beside the measured number, compound 3's estimate is 1.1-fold (0.02 log units) above it; the range from low to high includes it.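

The step at this aromatic nitrogen in this assay is a 1.6-fold lower number from compound 2 to compound 3 (0.22 log units; within the scatter), so putting cyclohexyl in place of hydrogen here leaves compound 3 within the scatter of compound 2. For the compounds shown here, this is the first reading at this position, and it shows that a non-aromatic carbon ring at this nitrogen can stand on the thiosemicarbazone compound without a step that can be told from the scatter, whereas the one change on an amine nitrogen gave an at least 3.5-fold lower number from compound 1 to compound 2 (0.55 log units; beyond the scatter). Compound 1 remains the only compound that offers a limit rather than a number: the limit of >= 100000 nM in this assay, at which 1 of the 3 values shown sits.

What the compounds shown leave open is whether a single methyl, a longer alkyl chain, a phenyl ring or a chain ending in an amine at this aromatic nitrogen would also stay within the scatter of compound 2. They also leave open whether cyclohexyl at the same nitrogen would give a comparable step on the carbonyl compound, compound 1, whose reading is only a limit.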